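Carbamate for Urea: Cytotoxicity Outlook for Compound 4

The compounds below may be only part of what the source reports. "The series", "measured", "known", "first", "only" and "open" are said of these compounds alone.

Compound 1, `CCN(CC)c1cc2[nH]c(C3CCCCC3)nc2cc1NC(=O)c1cnccn1`: > 100 ug/mL
Compound 2, `CCN(CC)c1cc2[nH]c(C3CCCCC3)nc2cc1NC(=O)c1ccc(F)cc1`: > 100 ug/mL
Compound 3, `CCCNC(=O)Nc1cc2nc(C3CCCCC3)[nH]c2cc1N(CC)CC`: > 100 ug/mL

In an ADME assay on Vero cells (Chlorocebus sabaeus) for cytotoxicity, read by resazurin assay, with a stated time of 3 days (on this read-out lower numbers stand for stronger inhibition and higher numbers for weaker inhibition), compound 1 gives > 100 ug/mL, which is a limit of the assay and not a number. Compound 2 gives > 100 ug/mL, again a limit. Compound 3 gives > 100 ug/mL, also a limit. Compound 3 therefore stands at the same limit as the other two, and no order among the three can be drawn from these values.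

Compound 4, `CCN(CC)c1cc2[nH]c(C3CCCCC3)nc2cc1NC(=O)OCCOCCOC`, differs from compound 3 by 2-(2-methoxyethoxy)ethoxy in place of propylamino on a carbonyl carbon. The measured steps at this carbonyl position are a step that the two limits leave unreadable from compound 1 to compound 3 and a step that the two limits leave unreadable from compound 2 to compound 3, and the third step that the two limits leave unreadable from compound 1 to compound 2 is of the same kind; none of them can be sized because of the limit of > 100 ug/mL in this assay, at which 3 of the 3 values shown sit. The three changes at this position, spanning a heteroaryl, an aryl and an alkylamino group, all stayed at the limit, so no step beyond the scatter is expected for compound 4 in this assay either. Compound 4 is expected to give about 150 ug/mL, in a range from 60 ug/mL to 400 ug/mL. The step that the limit leaves unreadable from compound 3 to compound 4 is accordingly estimated to be negligible, with the result most likely reported again as a limit.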

Compound 4, half-maximal inhibitory concentration: > 100 ug/mL
Compound 4: only a limit was reported; the forecaster's own chance of this, stated with the estimate: 85%; the middle value lies beyond the limit too.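

In this assay compound 4 gives > 100 ug/mL, which is a limit and not a number. For the compounds shown here, compound 1, compound 2 and compound 3 sit at that same limit, so no step to compound 4 can be read: the limit of > 100 ug/mL in this assay, at which 4 of the 4 values shown sit. The compounds shown leave open whether the groups on the carbonyl carbon differ at all in cytotoxicity.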